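Adding a chlorine to an inactive chalcone-like thiazole

The compounds below may be only part of what the source reports. "The series", "measured", "known", "first", "only" and "open" are said of these compounds alone.

This set of compounds shares a core in which an anilino-substituted thiazole carries a carbonyl linked through a double bond to a phenyl ring. Compound 3 `Cc1nc(Nc2ccccc2)sc1C(=O)/C=C/c1ccccc1` has a plain phenyl at the far end. In a functional assay on Bel-7402 cells (Homo sapiens) for cytotoxicity, read by MTT assay (on this read-out higher numbers stand for weaker inhibition and lower numbers for stronger inhibition), compound 3 gives > 25000 nM, which is a limit of the assay rather than a measured number. Compound 1 `Cc1ccccc1Nc1nc(C)c(C(=O)/C=C/c2ccccc2Cl)s1` gives > 25000 nM, again a limit. Compound 2 `Cc1cccc(Nc2nc(C)c(C(=O)/C=C/c3ccccc3Cl)s2)c1` gives > 25000 nM, also a limit. All three therefore share one position, (the limit of > 25000 nM in this assay, at which 3 of the 3 values shown sit).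

Going by the values given here, the only step with both ends measured, a step that the two limits leave unreadable from compound 1 to compound 2, changes a methylphenyl on the nitrogen and cannot be read in size, so no measured step speaks directly to the change considered here. Compound 4 `Cc1nc(Nc2ccccc2)sc1C(=O)/C=C/c1ccccc1Cl` differs from compound 3 as follows: chloro in place of hydrogen on an aromatic carbon. Compounds 1 and 2 already carry this 2-chlorophenyl with a different anilino group and both stay at the limit, which suggests the chlorine alone does not bring a readable number.

The step from compound 3 to compound 4 is therefore expected to be a step that the limit leaves unreadable from compound 3 to compound 4, and for compound 4 in this assay the estimate is 30000 nM, with a range from 10000 nM to 100000 nM.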

Compound 4, half-maximal inhibitory concentration: > 25000 nM
Compound 4: no number, only a limit (the forecaster's own chance of this, stated with the estimate: 80%); the middle value lies beyond the limit too.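

In this assay compound 4 gives > 25000 nM which is again a limit and not a number. Going by these compounds alone, no step among compound 1, compound 2, compound 3 and compound 4 can be read, as all four share one position: the limit of > 25000 nM in this assay, at which 4 of the 4 values shown sit. The compounds shown leave open which change to the shared core, if any, would bring a readable number.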